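Trifluoromethoxy in place of trifluoromethyl in compound 2

This account rests on a few compounds, and the source may have more. Where it says the series, first, only, none or still open, it means among the compounds named here.

Values in a functional assay on LNCaP cells (Homo sapiens) for antiproliferative activity, read by propidium iodide staining, with a stated time of 96 h; on this read-out higher numbers stand for weaker inhibition and lower numbers for stronger inhibition:
compound 1 `CC(O)(COc1ccc(S(F)(F)(F)(F)F)cc1)C(=O)Nc1cccc(S(F)(F)(F)(F)F)c1` gives 8000 nM
compound 2 `CC(O)(COc1ccc(C(F)(F)F)cc1)C(=O)Nc1cccc(S(F)(F)(F)(F)F)c1` gives 9600 nM
compound 3 `CC(O)(COc1cccc(C(F)(F)F)c1)C(=O)Nc1cccc(S(F)(F)(F)(F)F)c1` gives 28800 nM

Compound 2, at 9600 nM, stands close to compound 1 and has a lower number than compound 3. Compound 4 `CC(O)(COc1ccc(OC(F)(F)F)cc1)C(=O)Nc1cccc(S(F)(F)(F)(F)F)c1` carries trifluoromethoxy in place of trifluoromethyl on an aromatic carbon, para to a large group (trifluoromethoxy in place of trifluoromethyl on an aromatic carbon). Among the compounds with values here, the nearest precedent is the exchange of the group at this same place, a 1.2-fold higher number from compound 1 to compound 2 (0.08 log units; within the scatter). The modest step of a 3.0-fold higher number from compound 2 to compound 3 (0.48 log units; beyond the scatter) moved the trifluoromethyl group, and compound 4 involves no such move. The expected step, a 1.1-fold lower number from compound 2 to compound 4 (0.03 log units; within the scatter), is therefore none beyond the scatter. In this assay the estimate for compound 4 is 9000 nM, with an expected range of 4500 nM to 20000 nM.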

Compound 4, half-maximal inhibitory concentration: 12700 nM
Estimate against measurement, compound 4: 1.4-fold (0.15 log units) below; measured number inside the range.
By their numbers in this assay, from the lowest: compounds 1, 2 and 4 (each within the scatter of the next); then compound 3.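

In this assay, trifluoromethoxy on this aromatic carbon, para to a large group, gives a 1.3-fold higher number from compound 2 to compound 4 (0.12 log units; within the scatter) and a 1.6-fold higher number from compound 1 to compound 4 (0.20 log units; within the scatter), so all three groups tried at this place, including that of compound 1, lie within the scatter of one another. The entering oxygen adds a hydrogen-bond acceptor to the count, yet neither step goes beyond the scatter. No measurement is available that would explain this result.

From the compounds shown here alone, whether an amine or a carboxylic acid at this place would leave the number equally unmoved remains open. Also open, going by these compounds, is whether shifting trifluoromethoxy would repeat the step seen with the trifluoromethyl group of compound 3.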